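Chloro to hydroxy on the aromatic ring of the shared core

This account rests on a few compounds, and the source may have more. Where it says the series, first, only, none or still open, it means among the compounds named here.

Measured so far:
compound 1 `C=CC[C@H]1C[C@]2([C@@H](C)Cc3ccc(OC)c(C(=O)NC)c3)OCOC2=CC1=O`: 1100 nM
compound 2 `C=CC[C@H]1C[C@]2([C@@H](C)Cc3ccc(OC)c(Cl)c3)OCOC2=CC1=O`: 640 nM

In a functional assay on NCI-H460 cells (Homo sapiens) for antiproliferative activity, with a stated time of 72 h (on this read-out higher numbers stand for weaker inhibition and lower numbers for stronger inhibition), compound 2 holds the lower of the two numbers; its nearest neighbour is compound 1, and the step of a 1.7-fold lower number from compound 1 to compound 2 (0.24 log units; within the scatter) lies within the scatter. Compound 3 `C=CC[C@H]1C[C@]2([C@@H](C)Cc3ccc(OC)c(O)c3)OCOC2=CC1=O` is not yet measured. It differs from compound 2 by hydroxy in place of chloro on an aromatic carbon, the same aromatic carbon that carried the change from compound 1 to compound 2. That earlier step, a 1.7-fold lower number from compound 1 to compound 2 (0.24 log units; within the scatter), is the only one that bears on this site, and it did not move the number beyond the scatter. Among the measured compounds shown here, on that basis no clear shift is expected in this assay from compound 2 to compound 3; a small rise is taken as slightly more likely than a fall, but the range is kept wide because only one step, a 1.7-fold lower number from compound 1 to compound 2 (0.24 log units; within the scatter), informs it. The step is therefore estimated as a 1.4-fold higher number from compound 2 to compound 3 (0.15 log units; within the scatter). Compound 3 is expected to give 900 nM in this assay, with a range from 350 nM to 2500 nM.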

Compound 3, half-maximal inhibitory concentration: 80 nM
Estimate against measurement, compound 3: 11-fold (1.05 log units) above, and the stated range ends above it.
By their numbers in this assay, from the lowest: compound 3; then compounds 2 and 1 (each within the scatter of the next).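

In this assay this aromatic carbon proves sensitive to the group it carries, a point that the step of a 1.7-fold lower number from compound 1 to compound 2 (0.24 log units; within the scatter) within the scatter did not reveal. Hydroxy separates itself from both earlier groups with an 8.0-fold lower number from compound 2 to compound 3 (0.90 log units; beyond the scatter) and a 14-fold lower number from compound 1 to compound 3 (1.14 log units; beyond the scatter) and both steps lie beyond the scatter. Chloro leaves with no hydrogen-bond donor or acceptor and hydroxy enters with one of each, but no measurement here accounts for the lower number of compound 3.

The compounds shown leave open whether an amine or a carboxylic acid on this aromatic carbon would give a number close to that of compound 3. They also leave open whether the hydroxy step would keep its size with the methoxy group or the allyl chain of the shared core replaced.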